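Changing the Sulfonyl Group from Compound 3 to Compound 4

The source may report more compounds than this note shows. Statements on the series, on what has been measured and on what is new or still open speak of the compounds shown alone.

Compound 1 `O=C(NCc1ccc(S(=O)(=O)c2ccccc2)cc1)N1Cc2ccncc2C1` gives 7.5 mL/min/kg
Compound 2 `CCCn1cc(S(=O)(=O)c2ccc(CNC(=O)N3Cc4ccncc4C3)cc2)cn1` gives 11 mL/min/kg
Compound 3 `O=C(NCc1ccc(S(=O)(=O)C2CCC(F)(F)CC2)cc1)N1Cc2ccncc2C1` gives 6 mL/min/kg

In an ADME assay on microsomes from liver (Homo sapiens) for pharmacokinetics, read by LC-MS, with a stated time of 60 min, tested at 1 uM (on this read-out higher numbers stand for fast clearance and lower numbers for slow clearance), compound 3 stands within the scatter of the other two, with a 1.3-fold lower number from compound 1 to compound 3 (0.10 log units; within the scatter) and a 1.8-fold lower number from compound 2 to compound 3 (0.26 log units; within the scatter) as its steps. Compound 4 `CC(=O)N1CCC(S(=O)(=O)c2ccc(CNC(=O)N3Cc4ccncc4C3)cc2)CC1` has 1-acetylpiperidin-4-yl in place of 4,4-difluorocyclohexyl on a sulfonyl sulfur. Among the measured compounds shown here, no measured compound carries this group, so only the earlier exchanges on the sulfonyl sulfur bear on it. These are the two steps above and a 1.5-fold higher number from compound 1 to compound 2 (0.17 log units; within the scatter), all within the scatter. For compound 4 the estimated step is a 1.2-fold higher number from compound 3 to compound 4 (0.07 log units; within the scatter), so none beyond the scatter is expected. Compound 4 is expected at 7 mL/min/kg, within a range from 4 mL/min/kg to 13 mL/min/kg in this assay.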

Compound 4, clearance: 6 mL/min/kg
Estimate against measurement, compound 4: 1.2-fold (0.07 log units) above; the measured number falls inside the stated range.
By their numbers in this assay, from the lowest: compounds 3, 4, 1 and 2 (each within the scatter of the next).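

In this assay, 1-acetylpiperidin-4-yl on a sulfonyl sulfur gives no change at the digits printed from compound 3 to compound 4 (within the scatter), along with a 1.8-fold lower number from compound 2 to compound 4 (0.26 log units; within the scatter) and a 1.3-fold lower number from compound 1 to compound 4 (0.10 log units; within the scatter). Among the compounds shown here, a six-membered non-aromatic ring with a hetero atom and a hydrogen-bond acceptor thus joins the phenyl, 1-propyl-1H-pyrazol-4-yl and 4,4-difluorocyclohexyl groups, with every exchange at this position so far staying within the scatter. Nothing at hand explains this result. The compounds shown leave open whether any group here can move clearance beyond the scatter, such as a free piperidine amine or a carboxylic acid.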